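A few compounds are considered here, and "the series" means these few. Any claim that something is new, unique, unknown or untested is made for them only; others in the source may bear on it.

Measured compounds:
compound 1, `CC#C[C@@H](CC(=O)O)c1ccc(OC[C@H]2COc3c(Cl)cccc3O2)cc1`: 81%
compound 2, `CC#C[C@@H](CC(=O)O)c1ccc(OC[C@H]2COc3ccc(F)cc3O2)cc1`: 86%

In a functional assay on HEK293 cells for agonist activity at Free fatty acid receptor 1 (Homo sapiens), read by fluorescence and calcium flux, with a stated time of 10 min (a higher number here means a larger maximal response, a lower number a smaller maximal response), compound 2 gives 86%, and compound 1 gives 81%. These two numbers lie within the usual scatter of each other, so the data do not separate compound 2 from compound 1; both show a maximal response that falls somewhat short of the reference used in this assay. Going by the values given here, no step between the two has been worked out beyond that comparison.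

Compound 3, `CC#C[C@@H](CC(=O)O)c1ccc(OC[C@H]2COc3ccc(OC(C)C)cc3O2)cc1`, has not yet been measured in this assay. It differs from compound 2 at one place: isopropoxy in place of fluoro on an aromatic carbon. Among the compounds with values here, both measured compounds carry a halogen on the fused ring system, and no compound with an alkoxy group at that place has been measured, so there is nothing to anchor a direction. Given that compound 1 and compound 2 sit close together, no step beyond the scatter is expected from compound 2 to compound 3, and the estimated change is a number 4 percentage points lower from compound 2 to compound 3 (within the scatter). Compound 3 is therefore expected to reach about 82% in this assay, with a range from 65% to 98%.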

Compound 3, largest response reached (Emax), in percent of the reference or control that the assay uses: 90%
Beside the measured number, compound 3's estimate is 8 percentage points below it; the range from low to high includes it.
By their numbers in this assay, from the lowest: compounds 1, 2 and 3 (each within the scatter of the next).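

In this assay, isopropoxy in place of fluoro on this aromatic carbon gives a number 4 percentage points higher from compound 2 to compound 3 (within the scatter) and so does not separate the two compounds. Going by these compounds alone, this is the first look at an alkoxy group at this place. A single fluorine gives way to a branched group of 4 heavy atoms that adds a hydrogen-bond acceptor, and the maximal response still stays within the scatter, so the position accepts this much larger substituent with no measurable loss or gain in this read-out. Nothing at hand explains this outcome.

The compounds shown leave open whether an amine, a hydroxyl group or a longer alkoxy chain on this same aromatic carbon would move the maximal response beyond the scatter, and whether isopropoxy would behave the same way on another carbon of that ring. They also leave open whether this change affects anything other than the maximal response, such as the concentration needed to reach it.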